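Trimethoxyphenyl enones on a fused bicyclic core: para substituent swap

A few compounds are considered here, and "the series" means these few. Any claim that something is new, unique, unknown or untested is made for them only; others in the source may bear on it.

Measured so far:
compound 1, `COc1ccc(-c2nc3ccccn3c2/C=C/C(=O)c2cc(OC)c(OC)c(OC)c2)cc1`: 2380 nM
compound 2, `COc1cc(C(=O)/C=C/c2c(-c3ccc(F)cc3)nc3ncccn23)cc(OC)c1OC`: 1610 nM

In a functional assay on MCF7 cells (Homo sapiens) for inhibition, read by sulforhodamine B assay, with a stated time of 48 h (on this read-out higher numbers stand for weaker inhibition of growth and lower numbers for stronger inhibition of growth), compound 2 gives 1610 nM, and compound 1 gives 2380 nM. The two numbers lie within the scatter of each other, so no ranking between compound 1 and compound 2 is supported. Compound 3, `COc1ccc(-c2nc3ncccn3c2/C=C/C(=O)c2cc(OC)c(OC)c(OC)c2)cc1`, has not been measured. Compared with compound 2 it carries methoxy in place of fluoro on an aromatic carbon. For the measured compounds named here, with only two compounds measured and no step between them beyond the scatter, no direction is expected for this change: the step of a 1.2-fold higher number from compound 2 to compound 3 (0.09 log units; within the scatter) is estimated to stay within the scatter. Compound 3 is therefore expected to give about 2000 nM, with a range from 800 nM to 5000 nM.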

Compound 3, concentration for 50% growth inhibition: 1140 nM
Compound 3: the middle estimate sits 1.8-fold (0.24 log units) above what was measured; measured number inside the range.
By their numbers in this assay, from the lowest: compounds 3, 2 and 1 (each within the scatter of the next, the first and the last beyond it).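

In this assay, methoxy in place of fluoro on this aromatic carbon, para to a large group, gives a 1.4-fold lower number from compound 2 to compound 3 (0.15 log units; within the scatter) and so does not separate the two compounds. For the compounds shown here, this is the first single-place step, and on this read-out the position holds either 4-fluorophenyl or 4-methoxyphenyl without a readable difference. Nothing at hand bears on why this is so.

Still open, going by these compounds, is whether an amine or a carboxylic acid at this position would give a step beyond the scatter. On these data alone, the same swap on the core of compound 1 also remains open.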